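The source may hold more compounds than are shown below. What is called first, only, known or untested is meant among the compounds shown, and "the series" means these compounds.

Compound 1, `CC(=O)N(O)C(C)c1ccc2oc(-c3ccccc3)cc2c1`, and compound 2, `COc1cc(-c2cc3cc(C(C)N(O)C(C)=O)ccc3o2)cc(OC)c1OC`, share a core with a hydroxamic acid side chain; how the two cores differ is not broken down here. In an assay on RBL cells for inhibition of Polyunsaturated fatty acid 5-lipoxygenase (Rattus norvegicus) (on this read-out higher numbers stand for weaker inhibition and lower numbers for stronger inhibition), compound 1 gives 490 nM, and compound 2 gives 310 nM. These two values lie within the usual scatter of each other, so no ranking between them can be drawn.

Compound 3, `COC(=O)CCCC(=O)N(O)C(C)c1ccc2oc(-c3ccccc3)cc2c1`, is compound 1 with one change: 2-(methoxycarbonyl)ethyl in place of hydrogen on a saturated chain carbon bound to a carbonyl carbon. In this assay compound 3 gives 60 nM, which is an 8.2-fold lower number from compound 1 to compound 3 (0.91 log units; beyond the scatter). For the measured compounds named here, that is the only measured example of this change among the compounds here.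

Compound 4, `COC(=O)CCCC(=O)N(O)C(C)c1ccc2oc(-c3cc(OC)c(OC)c(OC)c3)cc2c1`, is not yet measured. It is built from compound 2 by the same change, (2-(methoxycarbonyl)ethyl in place of hydrogen on a saturated chain carbon bound to a carbonyl carbon), made at the same place as in compound 1 to compound 3. Going by the values given here, because the step of an 8.2-fold lower number from compound 1 to compound 3 (0.91 log units; beyond the scatter) was clear, the expected step from compound 2 to compound 4 is about a 6.9-fold lower number from compound 2 to compound 4 (0.84 log units; beyond the scatter), on the assumption that the change acts much alike on the two cores, even though only one example of the change is available and the two cores are not the same. On that basis compound 4 is expected to give roughly 45 nM in this assay, likely somewhere between 15 nM and 150 nM.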

Compound 4, half-maximal inhibitory concentration: 40 nM
For compound 4 the middle estimate is 1.1-fold (0.05 log units) above the measured one; the measured number falls inside the stated range.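

In this assay, putting 2-(methoxycarbonyl)ethyl in place of hydrogen on the saturated chain carbon bound to a carbonyl carbon gives a 7.8-fold lower number from compound 2 to compound 4 (0.89 log units; beyond the scatter), and this step can be set directly beside the one seen on the other core: the same change on two cores in this assay, an 8.2-fold lower number (0.91 log units; beyond the scatter) from compound 1 to compound 3 and a 7.8-fold lower number (0.89 log units; beyond the scatter) from compound 2 to compound 4, 1.1-fold (0.02 log units) apart, within the scatter of two such steps. The change therefore lowered the number by a closely similar amount on both cores, so a step measured on the core of compound 1 would have served as a good guide to the step on the core of compound 2. This does not show that the change will transfer in the same way to other cores, since the agreement rests on just two pairs of compounds in one assay, and the numbers alone do not explain why the added chain lowers the reading or which part of it matters.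

The compounds shown leave open how the result depends on the added chain itself, such as whether a shorter or longer chain would do the same, or whether a carboxylic acid or an amide could replace the methoxycarbonyl end. They also leave open whether a third core, carrying different groups, would show a step of similar size.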